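The compounds below may be only part of what the source reports. "The series", "measured", "known", "first", "only" and "open" are said of these compounds alone.

Measured in an assay on microsomes from intestine for inhibition of acyl-CoA:cholesterol acyltransferase (Oryctolagus cuniculus); a lower number here means a stronger inhibitor, a higher number a weaker inhibitor:
- compound 1 `CC(C)c1cccc(C(C)C)c1NC(=O)CC(=O)Oc1c(C(C)C)cccc1C(C)C` — compound 1 gives 42 nM
- compound 2 `CCCCCCCCCCOC(=O)CC(=O)Nc1c(C(C)C)cccc1C(C)C` — compound 2 gives 53 nM
- compound 3 `CC(C)c1cccc(C(C)C)c1NC(=O)CC(=O)OC(C)(C)C` — compound 3 gives 130 nM

Three esters of the same malonamide share the core of compound 2. In this assay compound 2 stands second highest of the three numbers. The value of compound 1 lies nearest to it, and the two sit within the scatter of each other, so nothing is made of their order. Within the data shown here, compound 3 gives a higher number than compound 2, and that gap lies beyond the scatter; no step between a pair of measured compounds is available, so only the two values themselves are taken as they stand.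

Compound 4 `CCCCCCCCCCCCCCCCCCOC(=O)CC(=O)Nc1c(C(C)C)cccc1C(C)C` is the next ester, not yet measured. Its change from compound 2 is octyl in place of hydrogen on a saturated chain carbon, ten or more bonds along the chain from an oxygen next to a carbonyl group. Among the measured compounds shown here, nothing among the measured compounds shows what a longer chain does here; the only chain comparison is the decyl of compound 2 against the aryl of compound 1, and those two lie within the scatter. The step from compound 2 to compound 4 is therefore expected to be small, likely toward a somewhat higher number, or none beyond the scatter. For compound 4 in this assay the estimate is 75 nM, with a range from 25 nM to 220 nM, which means an expected step of a 1.4-fold higher number from compound 2 to compound 4 (0.15 log units; within the scatter).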

Compound 4, half-maximal inhibitory concentration: 53 nM
For compound 4 the middle estimate is 1.4-fold (0.15 log units) above the measured one; low and high end bracket the measured number.
By their numbers in this assay, from the lowest: compounds 1, 2 and 4 (each within the scatter of the next); then compound 3.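

In this assay the series now has its first step in one place only: octyl in place of hydrogen on a saturated chain carbon, ten or more bonds along the chain from an oxygen next to a carbonyl group, brings no change at the digits printed from compound 2 to compound 4 (within the scatter). Among these compounds, this far along the chain, the position accepts the added octyl without a change beyond the scatter, something the earlier compounds, with no pair among them differing in one place, could not show. Nothing at hand accounts for the size of this step.

Open, on these data alone, is whether a shorter chain such as hexyl, or a branched chain of the same length, behaves the same way. Also open, as far as these compounds go, is whether this position accepts a chain ending in a carboxylic acid or an amine.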